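The source may report more compounds than this note shows. Statements on the series, on what has been measured and on what is new or still open speak of the compounds shown alone.

Compound 1 `C=CCOC(=O)c1ccc2[nH]c(NC(=O)OC)nc2c1`; compound 2 `C#CCOC(=O)c1ccc2[nH]c(NC(=O)OC)nc2c1`; compound 3 `COC(=O)Nc1nc2cc(C(=O)NCC(C)(C)C)ccc2[nH]1`. In a functional assay on L1210 cells (Mus musculus) for inhibition (a higher number here means a weaker inhibitor, a lower number a stronger inhibitor), compound 1 gives > 10000 nM, which is a limit of the assay and not a number. Compound 2 gives 10000 nM and compound 3 gives 8600 nM; the two lie within the scatter of each other, a 1.2-fold lower number from compound 2 to compound 3 (0.07 log units; within the scatter). The step from compound 1 is an at least 1.1-fold lower number from compound 1 to compound 3 (0.06 log units; that floor lies within the scatter).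

Compound 4 `COC(=O)Nc1nc2cc(C(=O)OCCC(C)C)ccc2[nH]1` differs from compound 3 in one place: isopentyloxy in place of neopentylamino on a carbonyl carbon. This runs the earlier exchanges backwards, from an amide to an ester, and those exchanges, a 1.2-fold lower number from compound 2 to compound 3 (0.07 log units; within the scatter) and an at least 1.1-fold lower number from compound 1 to compound 3 (0.06 log units; that floor lies within the scatter), stayed within the scatter. In this assay compound 4 is therefore expected to show no step beyond the scatter, a 1.1-fold higher number from compound 3 to compound 4 (0.04 log units; within the scatter), with an estimated 9500 nM between 4500 nM and 20000 nM.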

Compound 4, half-maximal inhibitory concentration: 10000 nM
Compound 4: middle estimate off by 1.1-fold (0.02 log units), on the low side, and the stated range covers the measured number.
By their numbers in this assay, from the lowest: compounds 3, 2 and 4 (each within the scatter of the next).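

On this carbonyl carbon, isopentyloxy (0 hydrogen-bond donors, 1 hydrogen-bond acceptor) in place of neopentylamino (1 hydrogen-bond donor, 0 hydrogen-bond acceptors) gives a 1.2-fold higher number from compound 3 to compound 4 (0.07 log units; within the scatter). Within the esters, a far larger change at the chain end, isobutyl in place of ethynyl, gives no change at the digits printed from compound 2 to compound 4 (within the scatter), so neither exchange separates these compounds in this assay. The remaining step is a number no higher from compound 1 to compound 4 (the limit leaves the size open). It cannot be read, because compound 1 stands at a limit of the assay: the limit of > 10000 nM in this assay, at which 1 of the 4 values shown sits.

As far as these compounds go, whether a carboxylic acid, an amine or a benzyl ester on this carbonyl carbon would move the number beyond the scatter remains open.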